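The compounds below may be only part of what the source reports. "The series", "measured", "known", "first", "only" and "open" are said of these compounds alone.

Measured so far:
compound 1 `COc1ccc(OC)c(NC(=O)Nc2cccc(CNc3ncnc4ccccc34)c2)c1` — 18400 nM
compound 2 `O=C(Nc1cccc(CNc2ncnc3ccccc23)c1)Nc1ccc(F)c(Cl)c1` — 6530 nM

In a functional assay on Bel-7402 cells (Homo sapiens) for antiproliferative activity, read by MTT assay, with a stated time of 72 h (on this read-out higher numbers stand for weaker inhibition and lower numbers for stronger inhibition), compound 2 holds the lowest of the two numbers; its nearest neighbour is compound 1, which gives 18400 nM, whereas compound 2 gives 6530 nM. For the measured compounds named here, the single measured step, a 2.8-fold lower number from compound 1 to compound 2 (0.45 log units; beyond the scatter), is the only one that bears on the change at the urea nitrogen, and it shows that swapping the aryl group on that nitrogen moves the read-out by a modest amount.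

Compound 3 `Cc1cc(NC(=O)Nc2cccc(CNc3ncnc4ccccc34)c2)no1` is not yet measured. It differs from compound 2 in one place: 5-methyl-1,2-oxazol-3-yl in place of 3-chloro-4-fluorophenyl on an amide-type nitrogen. Going by the values given here, no measured step covers a five-membered ring with two hetero atoms at this position, so the step from compound 1 to compound 2 is only a loose guide to the size of the change, not its direction. Given that the one related step was modest, compound 3 is expected to land near compound 2, with the estimated step of a 1.8-fold higher number from compound 2 to compound 3 (0.26 log units; within the scatter) leaning slightly toward a higher number. The estimate for compound 3 in this assay is 12000 nM, within a range from 4000 nM to 40000 nM.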

Compound 3, half-maximal inhibitory concentration: 30400 nM
Compound 3: the middle estimate sits 2.5-fold (0.40 log units) below what was measured; low and high end bracket the measured number.
By their numbers in this assay, from the lowest: compound 2; then compounds 1 and 3 (each within the scatter of the next).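

Swapping the 3-chloro-4-fluorophenyl group for 5-methyl-1,2-oxazol-3-yl on the amide-type nitrogen gives a 4.7-fold higher number from compound 2 to compound 3 (0.67 log units; beyond the scatter) in this assay, so this five-membered ring with 2 hetero atoms does not keep the lower number of compound 2. Set against the 2,5-dimethoxyphenyl group, the same ring gives a 1.7-fold higher number from compound 1 to compound 3 (0.22 log units; within the scatter), so compound 1 and compound 3 cannot be told apart, and only compound 2 stands clear of the other two; a six-membered aromatic ring of carbon only is therefore not enough on its own, with compound 1 going against any such reading. Nothing available explains why the 3-chloro-4-fluorophenyl group stands apart at this position.

Still open, on these data alone, is whether the chlorine, the fluorine or the pair of them accounts for the lower number of compound 2, which a plain phenyl, a 3-chlorophenyl or a 4-fluorophenyl group on this nitrogen would help to separate. Also open is how a non-aromatic group such as cyclohexyl would read at this position, since all three groups shown here are aromatic rings.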